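A few compounds are considered here, and "the series" means these few. Any claim that something is new, unique, unknown or untested is made for them only; others in the source may bear on it.

Measured compounds:
compound 1 `CCCNc1nc(N)c(C(=O)N=C(N)N)nc1Cl` — 24%
compound 2 `NC(N)=NC(=O)c1nc(Cl)c(NCc2ccccc2F)nc1N` — 26%

Both were tested in an assay for inhibition of acid-sensing ion channel 3 (Homo sapiens), read by patch clamp, tested at 1 uM; on this read-out lower numbers stand for less inhibition and higher numbers for more inhibition at the one concentration tested (going by the name of the read-out). Compound 1 gives the lower of the two numbers, but the gap to compound 2, a number 2 percentage points higher from compound 1 to compound 2 (within the scatter), is one the assay cannot tell apart from repeat scatter, so the two compounds read as alike. That step swaps a small chain group for a fluorinated aromatic ring on the carbon attached to the ring nitrogen, and it leaves the readout where it was.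

Compound 3 `NC(N)=NC(=O)c1nc(Cl)c(Sc2ccccc2)nc1N` is not yet measured. It differs from compound 1 in another way: phenylsulfanyl in place of propylamino on an aromatic carbon. The nitrogen-linked chain is gone and a sulfur-linked aromatic ring takes its place on the shared core. Among the measured compounds shown here, no measured step changes this part of the molecule in this manner; the only step known, from compound 1 to compound 2, touches a different position and stays within the scatter. Little basis for a sizeable shift exists, so the step from compound 1 to compound 3 is expected to be a number 6 percentage points higher from compound 1 to compound 3 (within the scatter), with wide uncertainty. Compound 3 is therefore estimated at 30%, between 10% and 55%.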

Compound 3, a percentage reported as inhibition, at one concentration (the size of the read-out at that concentration, not a potency): 11%
The estimate for compound 3 lay 19 percentage points above the measured number, and the stated range covers the measured number.
By their numbers in this assay, from the lowest: compound 3; then compounds 1 and 2 (each within the scatter of the next).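

In this assay, replacing propylamino with phenylsulfanyl on this aromatic carbon gives a number 13 percentage points lower from compound 1 to compound 3 (beyond the scatter), the only step shown here that lies beyond the usual scatter of repeat measurements. The earlier step, a number 2 percentage points higher from compound 1 to compound 2 (within the scatter), brought in a 2-fluorophenyl group but kept the nitrogen link to the shared core, so an aromatic ring in that form left the reading unchanged, while the step to compound 3 replaces the nitrogen link with sulfur and attaches the ring directly to that sulfur. Nothing measured here explains the lower number, so the result records what happened at this position without giving a reason for it.

Going by these compounds, because the link and the attached group change together in compound 3, the effect of each remains open: a phenylamino group would keep the directly attached ring with a nitrogen link, while a propylsulfanyl group would keep the propyl chain with a sulfur link. On these data alone, each number also comes from a single concentration, so how the compounds compare in potency remains open too.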